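Chloro to Benzamido on the Shared Core: Vero Cell Cytotoxicity

The source may hold more compounds than are shown below. What is called first, only, known or untested is meant among the compounds shown, and "the series" means these compounds.

Three measured compounds share one core. Compound 1 `COc1cccc(-c2csc(NC(=O)c3ccco3)n2)c1` carries a methoxy group in place of the halogen seen in the others. In an ADME assay on Vero cells (Chlorocebus sabaeus) for cytotoxicity, read by MTT assay, with a stated time of 72 h (a lower number here means a stronger inhibitor, a higher number a weaker inhibitor), compound 1 reaches only the limit of the assay, > 90000 nM. Compound 2 `O=C(Nc1nc(-c2cccc(F)c2)cs1)c1ccc([N+](=O)[O-])o1` gives 51600 nM in this assay. Compound 3 `O=C(Nc1nc(-c2cccc(Cl)c2)cs1)c1ccc([N+](=O)[O-])o1` gives 43700 nM in this assay. Within the data shown here, the single step between fully measured compounds, a 1.2-fold lower number from compound 2 to compound 3 (0.07 log units; within the scatter), means compound 3 and compound 2 cannot be told apart; the third value shown is a limit, (the limit of > 90000 nM in this assay, at which 1 of the 3 values shown sits).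

Compound 4 `O=C(Nc1cccc(-c2csc(NC(=O)c3ccc([N+](=O)[O-])o3)n2)c1)c1ccccc1` differs from compound 3 in one place: benzamido in place of chloro on an aromatic carbon. Among the measured compounds shown here, no measured step involves benzamido, and the one step known, chloro for fluoro, lies within the scatter and does not bear on this larger change. The expectation for this assay is therefore a step of a 1.1-fold lower number from compound 3 to compound 4 (0.04 log units; within the scatter) that stays within the scatter, in no firm direction. Compound 4 is estimated at 40000 nM, with a range from 15000 nM to 90000 nM.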

Compound 4, half-maximal inhibitory concentration: 50200 nM
Beside the measured number, compound 4's estimate is 1.3-fold (0.10 log units) below it, and the stated range covers the measured number.
By their numbers in this assay, from the lowest: compounds 3, 4 and 2 (each within the scatter of the next). At a limit, above all of these: compound 1.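

In this assay, putting benzamido in place of chloro gives a 1.1-fold higher number from compound 3 to compound 4 (0.06 log units; within the scatter), and putting it in place of fluoro gives a 1.0-fold lower number from compound 2 to compound 4 (0.01 log units; within the scatter). The earlier compounds shown here compared only two single halogen atoms; these steps show that a far larger group, with a second six-membered aromatic ring, a hydrogen-bond donor and a hydrogen-bond acceptor, can sit at this aromatic carbon with no change that can be told from the scatter. Nothing measured here accounts for this absence of a change.

From the compounds shown here alone, what remains open is whether any group at this place can move the number beyond the scatter. An amine, a carboxylic acid or a longer chain on this aromatic carbon might do so, and the compounds shown cannot say.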